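Isopropyl on the amine nitrogen across two cores

The source may report more compounds than this note shows. Statements on the series, on what has been measured and on what is new or still open speak of the compounds shown alone.

Compound 1 `N=C(N)c1ccc2oc(-c3cccc(OCCCCOc4ccccc4)c3)cc2c1` is the reference with hydrogen on the amine nitrogen. In an ADME assay on L6 cells (Rattus norvegicus) for cytotoxicity, read by resazurin assay, with a stated time of 70 h (on this read-out lower numbers stand for stronger inhibition and higher numbers for weaker inhibition), compound 1 gives 8100 nM. Compound 2 `CC(C)NC(=N)c1ccc2oc(-c3cccc(OCCCCOc4ccccc4)c3)cc2c1` differs from it by isopropyl in place of hydrogen on an amine nitrogen; in this assay compound 2 gives 36500 nM, which is a 4.5-fold higher number from compound 1 to compound 2 (0.65 log units; beyond the scatter). Compound 3 `N=C(N)c1ccc2oc(-c3cccc(OCCCCCOc4ccccc4)c3)cc2c1` keeps hydrogen on the amine nitrogen, and its core differs from the core of compound 1 by phenoxymethyl in place of phenoxy on a saturated chain carbon, four bonds along the chain from an oxygen on an aromatic ring. In this assay compound 3 gives 3000 nM, which is a 2.7-fold lower number from compound 1 to compound 3 (0.43 log units; beyond the scatter); compound 3 stands lowest of the three measured numbers, with compound 1 nearest and compound 2 furthest from it.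

Compound 4 `CC(C)NC(=N)c1ccc2oc(-c3cccc(OCCCCCOc4ccccc4)c3)cc2c1` is not yet measured. It differs from compound 3 by isopropyl in place of hydrogen on an amine nitrogen, the change that also turns compound 1 into compound 2, made here on the core of compound 3. The place is described in identical words for both pairs, so this is the same change and not merely the same kind. Within the data shown here, only the pair compound 1 to compound 2 gives a measured instance of it, a thin basis.

Among the measured compounds shown here, the step of a 4.5-fold higher number from compound 3 to compound 4 (0.65 log units; beyond the scatter) is expected to resemble the earlier one; this rests on compound 1 and compound 2, where a 4.5-fold higher number from compound 1 to compound 2 (0.65 log units; beyond the scatter) is the sole measured instance of the change. Compound 4 is accordingly estimated at 13500 nM in this assay, with a likely range from 6500 nM to 28000 nM.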

Compound 4, half-maximal inhibitory concentration: 10100 nM
Compound 4: middle estimate off by 1.3-fold (0.13 log units), on the high side; the range from low to high includes it.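

In this assay, isopropyl in place of hydrogen on the amine nitrogen gives a 3.4-fold higher number from compound 3 to compound 4 (0.53 log units; beyond the scatter), so the change carries to the core of compound 3 with the same direction and a size that cannot be told apart from the first instance: the same change on two cores in this assay, a 4.5-fold higher number (0.65 log units; beyond the scatter) from compound 1 to compound 2 and a 3.4-fold higher number (0.53 log units; beyond the scatter) from compound 3 to compound 4, 1.3-fold (0.13 log units) apart, within the scatter of two such steps. Phenoxymethyl in place of phenoxy on the chain gives a 3.6-fold lower number from compound 2 to compound 4 (0.56 log units; beyond the scatter), so the chain change also holds when the amine nitrogen carries isopropyl rather than hydrogen: the same change on two cores in this assay, a 2.7-fold lower number (0.43 log units; beyond the scatter) from compound 1 to compound 3 and a 3.6-fold lower number (0.56 log units; beyond the scatter) from compound 2 to compound 4, 1.3-fold (0.13 log units) apart, within the scatter of two such steps. These two comparisons rest on the same four compounds and therefore form one closed set rather than two independent confirmations; they show additive behaviour of the two changes on these two cores in this one cytotoxicity read-out, and they do not show that the isopropyl step would hold on a core that differs elsewhere.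

The compounds shown leave open whether a different group on the amine nitrogen, such as ethyl or cyclopentyl, would give a step of similar size. They also leave open whether the isopropyl step persists on a longer chain, or where a pyridine ring stands in place of the terminal phenyl ring.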